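A few compounds are considered here, and "the series" means these few. Any claim that something is new, unique, unknown or untested is made for them only; others in the source may bear on it.

Measured in a functional assay on the whole organism (strain Kunming) with Mus musculus as the target, in the formalin test, with a stated time of 0.5 h; a lower number here means that less compound is needed, a higher number that more compound is needed for the effect:
- compound 1 `COc1ccccc1/C=C/C(=O)OC/C=C/c1cc(OC)c(OC)cc1OC`: 294 umol/kg
- compound 2 `COc1cc(OC)c(OC)cc1/C=C/COC(=O)/C=C/c1ccc(F)cc1`: 117 umol/kg

Compound 2 stands lowest of the two numbers, at 117 umol/kg. Not yet measured is compound 3 `COc1cccc(/C=C/C(=O)OC/C=C/c2cc(OC)c(OC)cc2OC)c1`, which shares the core of compound 2. The change is 3-methoxyphenyl in place of 4-fluorophenyl on a double-bonded chain carbon bound to a double-bonded chain carbon: 3-methoxyphenyl in place of 4-fluorophenyl, on a double-bonded chain carbon bound to a double-bonded chain carbon.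

Going by the values given here, only one measured step bears on this change, and it is modest: a 2.5-fold lower number from compound 1 to compound 2 (0.40 log units; beyond the scatter). That step also exchanges a methoxyphenyl group and 4-fluorophenyl at the same place, but there the group is 2-methoxyphenyl, not 3-methoxyphenyl. Among the compounds with values here, no measured compound carries 3-methoxyphenyl, so the data do not show how the two methoxyphenyl groups compare. Reading that step backwards, a higher number is expected in this assay, of similar or smaller size, and it may stay within the scatter. The estimated step is a 1.7-fold higher number from compound 2 to compound 3 (0.23 log units; within the scatter). The expected value for compound 3 is 200 umol/kg, with an estimated range from 90 umol/kg to 420 umol/kg.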

Compound 3, dose for half-maximal effect: > 260 umol/kg
Compound 3 gave a limit, no number; the forecaster's own chance of this, stated with the estimate: 3%; at least 1.3-fold (0.11 log units) between middle value and limit.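

In this assay, 3-methoxyphenyl in place of 4-fluorophenyl on a double-bonded chain carbon bound to a double-bonded chain carbon gives an at least 2.2-fold higher number from compound 2 to compound 3 (0.34 log units; beyond the scatter). Together with a 2.5-fold lower number from compound 1 to compound 2 (0.40 log units; beyond the scatter), this puts both methoxyphenyl compounds on the higher-number side of compound 2, so at this place the 4-fluorophenyl group now holds the lowest number against two different methoxyphenyl groups, not just one. The reading for compound 3 is a limit and not a number: the limit of > 260 umol/kg in this assay, at which 1 of the 3 values shown sits. The step between compound 1 and compound 3 cannot be read, so the 2-methoxyphenyl and 3-methoxyphenyl groups remain unranked.

The compounds shown leave open whether the lower number of compound 2 comes with the fluorine itself or with the absence of a methoxy group, which a plain phenyl group at the same place would help to separate. Also open, going by these compounds, is how an amine or a carboxylic acid on this phenyl ring would read in this assay, and whether the order seen here would hold with a different group on the other side of the shared core.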